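Replacing 5-bromo-1H-indol-3-yl with 2-methoxyphenyl

The compounds below may be only part of what the source reports. "The series", "measured", "known", "first", "only" and "open" are said of these compounds alone.

In a functional assay on DU-145 cells (Homo sapiens) for inhibition, read by trypan blue exclusion, with a stated time of 96 h (a lower number here means a stronger inhibitor of growth, a higher number a weaker inhibitor of growth), compound 3 (`Cc1ccc(CS/C(=C/c2c[nH]c3ccc(Br)cc23)C(=O)c2ccc(Cl)cc2)cc1`) gives 1000 nM as its value. That is level with compound 1 (`COc1ccccc1/C=C(/SCc1ccc(Cl)cc1)C(=O)c1ccc(Cl)cc1`) at 1000 nM on the same measure, while compound 2 (`Cc1ccc(CS/C(=C/c2ccccc2F)C(=O)c2ccc(Cl)cc2)cc1`) sits higher at 10000 nM in this test. Compound 4 (`COc1ccccc1/C=C(/SCc1ccc(C)cc1)C(=O)c1ccc(Cl)cc1`) has yet to be measured. It has 2-methoxyphenyl in place of 5-bromo-1H-indol-3-yl on a double-bonded chain carbon bound to a double-bonded chain carbon. For the measured compounds named here, one measured step bears on this change: a 10-fold lower number from compound 2 to compound 3 (1.00 log units; beyond the scatter) when 5-bromo-1H-indol-3-yl replaced 2-fluorophenyl. Losing that group could therefore raise the number. However, compound 4 shares 2-methoxyphenyl with compound 1, which gives 1000 nM despite differing elsewhere. A slightly higher number in this assay is therefore expected, with no change beyond the scatter. The estimated change is a 1.5-fold higher number from compound 3 to compound 4 (0.18 log units; within the scatter) and is expected to stay within the scatter. For compound 4 the estimated value is 1500 nM with an expected range from 400 nM to 6000 nM in this test.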

Compound 4, concentration for 50% growth inhibition: 10000 nM
Estimate against measurement, compound 4: 6.7-fold (0.82 log units) below, and the stated range ends below it.
By their numbers in this assay, from the lowest: compounds 1 and 3 (each within the scatter of the next); then compounds 2 and 4 (each within the scatter of the next).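

In this assay the 2-methoxyphenyl group does not hold its value when methyl replaces chloro on an aromatic carbon, a change giving a 10-fold higher number from compound 1 to compound 4 (1.00 log units; beyond the scatter), so what this group gives at the double-bonded chain carbon depends on what the molecule carries elsewhere. With methyl kept, methoxy in place of fluoro gives no change at the digits printed from compound 2 to compound 4 (within the scatter), whereas leaving 5-bromo-1H-indol-3-yl gives a 10-fold higher number from compound 3 to compound 4 (1.00 log units; beyond the scatter), which sets that group apart from both phenyl groups in this methyl series. The data shown offer no measured explanation for these steps.

Still open, as far as these compounds go, is whether 5-bromo-1H-indol-3-yl would lower the number further when paired with chloro in place of methyl. Also open, from the compounds shown here alone, is how the bromine contributes, and how an amine or a carboxylic acid would fare at this place.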